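Aryl swap at the saturated ring carbon: compound 4

A few compounds are considered here, and "the series" means these few. Any claim that something is new, unique, unknown or untested is made for them only; others in the source may bear on it.

Three members of the series have been run in a functional assay on the whole organism (strain Wister albino) for inhibition, with Rattus norvegicus as the target, read by paw edema, with a stated time of 1 h, at a dose of 50 mg/kg by the intraperitoneal route; a lower number here means less inhibition, a higher number more inhibition at the dose given (going by the name of the read-out). Compound 1 `Cc1ccc([C@@H]2CN(C)[C@]3(C(=O)Nc4ccccc43)[C@]23Cc2ccccc2C3=O)cc1` gives 56.4%. Compound 2 `CN1C[C@@H](c2ccccc2)[C@@]2(Cc3ccccc3C2=O)[C@@]12C(=O)Nc1ccccc12` gives 56%. Compound 3 `CN1C[C@@H](c2cccs2)[C@@]2(Cc3ccccc3C2=O)[C@@]12C(=O)Nc1ccccc12` gives 49.9%. Compound 3 carries the lowest of the three numbers, but the gaps are small: a number 6.1 percentage points lower from compound 2 to compound 3 (within the scatter) and a number 6.5 percentage points lower from compound 1 to compound 3 (within the scatter), so no order among the three can be read from them.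

Compound 4 `CN1C[C@@H](c2ccc(Cl)cc2)[C@@]2(Cc3ccccc3C2=O)[C@@]12C(=O)Nc1ccccc12` is the next entry. Relative to compound 3 the change is 4-chlorophenyl in place of thiophen-2-yl on a saturated ring carbon.

Among the compounds with values here, two measured steps touch the same position: a number 6.1 percentage points lower from compound 2 to compound 3 (within the scatter) (thiophen-2-yl in place of phenyl) and a number 6.5 percentage points lower from compound 1 to compound 3 (within the scatter) (thiophen-2-yl in place of 4-methylphenyl), both inside the scatter. A substituent on the aromatic ring has been varied once, a number 0.4 percentage points lower from compound 1 to compound 2 (within the scatter), again inside the scatter. Compound 4 returns to a six-membered carbon-only ring with a ring substituent, so in this assay no step beyond the scatter is expected in either direction.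

Compound 4 is expected to give 54%, with a range from 44% to 64%. The expected step of a number 4.1 percentage points higher from compound 3 to compound 4 (within the scatter) lies within the scatter.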

Compound 4, a percentage reported as inhibition, in the whole organism at one dose (the size of the read-out at that dose, not a potency): 27.9%
The estimate for compound 4 lay 26.1 percentage points above the measured number, outside the stated range (below it).
By their numbers in this assay, from the lowest: compound 4; then compounds 3, 2 and 1 (each within the scatter of the next).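

In this assay, within the data shown here, this saturated ring carbon had so far carried phenyl, 4-methylphenyl and thiophen-2-yl with no step beyond the scatter, so compound 4 holds the first change here that clearly moves the number: a number 28.1 percentage points lower from compound 2 to compound 4 (beyond the scatter) with chloro in place of hydrogen on an aromatic carbon and a number 28.5 percentage points lower from compound 1 to compound 4 (beyond the scatter) with chloro in place of methyl. The swap from thiophen-2-yl to 4-chlorophenyl is also beyond the scatter, a number 22 percentage points lower from compound 3 to compound 4 (beyond the scatter), which sets compound 4 apart from the other three compounds at this dose. Nothing available here accounts for the drop.

As far as these compounds go, whether the drop belongs to chloro alone remains open, since fluoro, bromo or methoxy on the same aromatic carbon would be needed to tell. A single dose and time also leave open how compound 4 behaves at other doses or later times.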